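A Second Methyl Group: From Compound 2 to Compound 3

A few compounds are considered here, and "the series" means these few. Any claim that something is new, unique, unknown or untested is made for them only; others in the source may bear on it.

Compound 2 `Cc1cccc(-c2ccc(C(=O)NCCCCc3cccnc3)cc2)c1`: 500 nM
Compound 1 `COc1ccc(-c2ccc(C(=O)NCCCCc3cccnc3)cc2Br)cc1OC`: 220 nM

Among the compounds with values here, in an assay (Canis lupus familiaris) for binding affinity to platelet-activating factor receptor (Homo sapiens), read by radioligand binding (on this read-out higher numbers stand for weaker inhibition and lower numbers for stronger inhibition), compound 2 gives 500 nM, the highest of the two numbers known. The nearest is compound 1, which in this assay gives 220 nM, a gap beyond the usual scatter. Compound 3 `Cc1ccc(-c2ccc(C(=O)NCCCCc3cccnc3)cc2)cc1C` differs from compound 2 in one place: methyl in place of hydrogen on an aromatic carbon. Within the data shown here, no measured pair shows this change, so the expected step is small, in no set direction, and likely within the scatter, giving no change at the digits printed from compound 2 to compound 3 (within the scatter). Compound 3 is therefore estimated at 500 nM, between 200 nM and 1300 nM.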

Compound 3, half-maximal inhibitory concentration: 200 nM
Compound 3: the middle estimate sits 2.5-fold (0.40 log units) above what was measured, within the range that was stated.
By their numbers in this assay, from the lowest: compounds 3 and 1 (each within the scatter of the next); then compound 2.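

Placing a methyl on the aromatic carbon ortho to a methyl group and para to a large group, which turns 3-methylphenyl into 3,4-dimethylphenyl, gives in this assay a 2.5-fold lower number from compound 2 to compound 3 (0.40 log units; beyond the scatter). Within the data shown here, this single-place change therefore lowers the number by a modest step, and it is the first such step available here. Nothing measured here accounts for the step.

On these data alone, whether an ethyl group, a chlorine atom or an amine at this position would move the number further remains open. Also open, as far as these compounds go, is whether this methyl would give a similar step without the neighbouring methyl already present.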